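Removing the Linking Sulfur from a Pentyl Side Chain

The source may hold more compounds than are shown below. What is called first, only, known or untested is meant among the compounds shown, and "the series" means these compounds.

Of the compounds shown here, three sharing one amide core have been measured in an assay on cells for antagonist activity at transient receptor potential cation channel subfamily V member 1 (Homo sapiens), read by FLIPR and calcium flux, with a stated time of 6 min; a lower number here means a stronger inhibitor, a higher number a weaker inhibitor. Compound 1 `CCOc1nc(C(C)(C)C)ccc1CNC(=O)C(C)c1ccc(NS(C)(=O)=O)c(F)c1` gives 14.8 nM in this assay. Compound 2 `CCCOc1nc(C(C)(C)C)ccc1CNC(=O)C(C)c1ccc(NS(C)(=O)=O)c(F)c1` gives 1.7 nM, and compound 3 `CCCCCSc1nc(C(C)(C)C)ccc1CNC(=O)C(C)c1ccc(NS(C)(=O)=O)c(F)c1` gives 3.1 nM. Among these three numbers compound 3 stands second highest: its nearest neighbour is compound 2, a gap within the scatter, and its furthest is compound 1, a gap beyond the scatter. The steps behind this are an 8.7-fold lower number from compound 1 to compound 2 (0.94 log units; beyond the scatter), a 4.8-fold lower number from compound 1 to compound 3 (0.68 log units; beyond the scatter) and a 1.8-fold higher number from compound 2 to compound 3 (0.26 log units; within the scatter).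

Compound 4 `CCCCCc1nc(C(C)(C)C)ccc1CNC(=O)C(C)c1ccc(NS(C)(=O)=O)c(F)c1` is not yet measured. It differs from compound 3 in one place: pentyl in place of pentylsulfanyl on an aromatic carbon. Going by the values given here, the step that bears most directly on it is the one from compound 2 to compound 3, in which the linking atom changed together with the chain and the number moved only within the scatter. The two larger steps, from compound 1 to compound 2 and from compound 1 to compound 3, both involved lengthening the chain, which compound 4 does not do. Among the compounds with values here, no measured step removes the linking atom altogether, so the expectation rests on the closeness of compounds 2 and 3. For compound 4 the estimate is therefore 3.5 nM, with a range from 1.2 nM to 10 nM, meaning an expected step of a 1.1-fold higher number from compound 3 to compound 4 (0.05 log units; within the scatter), a change within the scatter in either direction.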

Compound 4, inhibition constant: 1.9 nM
Compound 4: the middle estimate sits 1.8-fold (0.27 log units) above what was measured, within the range that was stated.
By their numbers in this assay, from the lowest: compounds 2, 4 and 3 (each within the scatter of the next); then compound 1.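

In this assay the result shows that the linking sulfur can be removed from this position, next to the ring nitrogen, without a readable effect: the change to pentyl gives (a 1.6-fold lower number from compound 3 to compound 4 (0.21 log units; within the scatter)), which lies within the scatter, even though the count of hydrogen-bond acceptors in the group falls from 1 to 0. Compound 4 also cannot be told apart from the propoxy compound (a 1.1-fold higher number from compound 2 to compound 4 (0.05 log units; within the scatter)), so a chain joined directly through carbon serves here as well as the chains joined through oxygen or sulfur in compound 2 and compound 3. Only the ethoxy compound stands apart (a 7.8-fold lower number from compound 1 to compound 4 (0.89 log units; beyond the scatter)), a step beyond the scatter, and this makes a linking oxygen or sulfur no requirement at this position among these four compounds.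

Nothing measured alongside these numbers accounts for them. The compounds shown leave open how a shorter all-carbon chain such as propyl, a longer one such as heptyl, or an amine joined at the same aromatic carbon would compare with pentyl.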